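This account rests on a few compounds, and the source may have more. Where it says the series, first, only, none or still open, it means among the compounds named here.

Compound 2 `COC(=O)[C@@]1(C)CC[C@@H]2C3=C1CC[C@@H](C)[C@]3(C)C[C@@H]1c3cc(Cl)ccc3N[C@H]21` carries a chloro on an aromatic carbon of the shared core, where compound 1 `COC(=O)[C@@]1(C)CC[C@@H]2C3=C1CC[C@@H](C)[C@]3(C)C[C@@H]1c3ccccc3N[C@H]21` carries hydrogen. In a functional assay on HeLa cells (Homo sapiens) for inhibition, read by sulforhodamine B assay, with a stated time of 48 h (a lower number here means a stronger inhibitor of growth, a higher number a weaker inhibitor of growth), compound 1 gives 19000 nM, and in this assay compound 2 gives 23000 nM; the step of a 1.2-fold higher number from compound 1 to compound 2 (0.08 log units; within the scatter) lies within the scatter. Compound 2 thus holds the highest of the two numbers shown, with compound 1 its nearest neighbour inside the scatter. Compound 3 `COC(=O)[C@@]1(C)CC[C@@H]2C3=C1CC[C@@H](C)[C@]3(C)C[C@@H]1c3cc(OC)ccc3N[C@H]21` differs from compound 2 by methoxy in place of chloro on an aromatic carbon. For the measured compounds named here, the only measured step that bears on this place is the exchange of hydrogen for chloro, which moved the number by no more than the scatter; a second exchange at the same place is therefore expected to give no step beyond the scatter in this assay, in no clear direction. The expected step is a 1.2-fold lower number from compound 2 to compound 3 (0.06 log units; within the scatter). Compound 3 is accordingly estimated at 20000 nM, within a range from 8000 nM to 50000 nM.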

Compound 3, concentration for 50% growth inhibition: 20000 nM
Beside the measured number, compound 3's estimate shows no gap at the digits printed; measured number inside the range.
By their numbers in this assay, from the lowest: compounds 1, 3 and 2 (each within the scatter of the next).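

In this assay this place, on an aromatic carbon of the shared core, has now taken a second group: methoxy in place of chloro gives a 1.2-fold lower number from compound 2 to compound 3 (0.06 log units; within the scatter) and methoxy in place of hydrogen gives a 1.1-fold higher number from compound 1 to compound 3 (0.02 log units; within the scatter). Methoxy enters with two heavy atoms and one hydrogen-bond acceptor where chloro has one heavy atom and no acceptor, yet hydrogen, chloro and methoxy all stand within the scatter of one another. Nothing at hand explains why these three compounds read alike.

As far as these compounds go, whether an amine, a carboxylic acid or a longer chain at this place would give a step beyond the scatter remains open. From the compounds shown here alone, it is also open whether the same holds on the other aromatic carbons of this ring, or whether a change elsewhere on the shared core, such as to its methyl ester, would move the number.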